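The source may report more compounds than this note shows. Statements on the series, on what has been measured and on what is new or still open speak of the compounds shown alone.

Measured so far:
Compound 1 `Clc1cccc(CSc2nnc(-c3ccncc3)n2-c2ccccc2)c1`: 11200 nM
Compound 2 `Fc1cccc(F)c1CSc1nnc(-c2ccncc2)n1-c1ccccc1`: a limit, > 50000 nM
Compound 3 `COc1ccc(/C=N/NC(=O)CSc2nnc(-c3ccncc3)n2-c2ccccc2)cc1`: 27100 nM

Of the compounds shown here, three share one core and have been measured in a functional assay on HepG2 cells (Homo sapiens) for inhibition, read by MTT assay, with a stated time of 48 h; a lower number here means a stronger inhibitor, a higher number a weaker inhibitor. Compound 1 gives 11200 nM. Compound 2 reaches only the limit of > 50000 nM, which is a limit of the assay and not a number. Compound 3 gives 27100 nM, the highest of the two numbers read; its nearest neighbour is compound 1, whose number is lower beyond the scatter. Going by the values given here, the only step measured between compounds differing in a single place is an at least 4.4-fold higher number from compound 1 to compound 2 (0.64 log units; beyond the scatter), which concerns a different part of the molecule, and one of its two values sits at the limit of > 50000 nM in this assay, at which 1 of the 3 values shown sits.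

Compound 4 `O=C(CSc1nnc(-c2ccncc2)n1-c1ccccc1)N/N=C/c1cc(Br)ccc1O` differs from compound 3 in one place: 5-bromo-2-hydroxyphenyl in place of 4-methoxyphenyl on a carbon with a double bond to nitrogen. Among the compounds with values here, no measured step touches this carbon, so nothing here points to a shift beyond the scatter in either direction. The expected step is a 1.4-fold lower number from compound 3 to compound 4 (0.13 log units; within the scatter). Compound 4 is estimated at 20000 nM, with a range from 6000 nM to 50000 nM.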

Compound 4, half-maximal inhibitory concentration: 4390 nM
Compound 4: middle estimate off by 4.6-fold (0.66 log units), on the high side; the measured number lies below the stated range.
By their numbers in this assay, from the lowest: compound 4; then compound 1; then compound 3. At a limit, above all of these: compound 2.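

In this assay, going by these compounds alone, the change on the carbon with a double bond to nitrogen gives a 6.2-fold lower number from compound 3 to compound 4 (0.79 log units; beyond the scatter), so the group at this place can move the number beyond the scatter, something no earlier step could show. The step is not a single change, since 5-bromo-2-hydroxyphenyl brings in a bromine and a hydrogen-bond donor while 4-methoxyphenyl has neither, and this one pair cannot tell these apart. Nothing measured here explains why the number falls.

Going by these compounds, it remains open whether the bromine or the hydroxy group alone would give a similar number. On these data alone, it also remains open whether an amine or a carboxylic acid on this ring would lower the number further or raise it again.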